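The compounds below may be only part of what the source reports. "The series", "measured", "known", "first", "only" and "open" are said of these compounds alone.

Measured so far:
compound 1 `COC(=O)/C=C/c1cccc(N(Cc2ccc(-c3cccc(C)c3)cc2)C(=O)C2CCCCC2)c1` — 109 nM
compound 2 `COC(=O)/C=C/c1cccc(N(Cc2cccc(Br)c2)C(=O)C2CCCCC2)c1` — > 1000 nM
compound 3 `COC(=O)/C=C/c1cccc(N(Cc2ccc(Br)cc2)C(=O)C2CCCCC2)c1` — > 1000 nM

In an assay on isolated protein with Bile acid receptor (Homo sapiens) as the target (on this read-out higher numbers stand for an effect only at larger amounts of compound and lower numbers for an effect already at smaller amounts), compound 1 gives 109 nM. For compound 2 the assay reports only a limit, > 1000 nM. For compound 3 the assay likewise reports only a limit, > 1000 nM. Compound 3 thus stands at the limit where two of the three values sit, (the limit of > 1000 nM in this assay, at which 2 of the 3 values shown sit), and no number of its own is known. Going by the values given here, the step of an at least 9.1-fold higher number from compound 1 to compound 3 (0.96 log units; beyond the scatter) is the only measured step that is readable; the step that the two limits leave unreadable from compound 2 to compound 3 cannot be sized from two limits.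

Compound 4 `COC(=O)/C=C/c1cccc(N(Cc2ccc(C(C)(C)C)cc2)C(=O)C2CCCCC2)c1` differs from compound 3 by tert-butyl in place of bromo on an aromatic carbon. The readable step bears on it only in part: it shows that a group other than bromo at the same position can carry the number well below the limit, but the group that enters here is not the 3-methylphenyl of compound 1. A move to a lower number is therefore expected, its size uncertain. Compound 4 is expected to give 450 nM, between 120 nM and 2000 nM. The expected step is an at least 2.2-fold lower number from compound 3 to compound 4 (0.34 log units; beyond the scatter).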

Compound 4, half-maximal effective concentration: > 1000 nM
Compound 4: a limit, no number (the forecaster's own chance of this, stated with the estimate: 35%); middle value at least 2.2-fold (0.34 log units) from the limit.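

Compound 4 gives only a limit in this assay, so tert-butyl joins bromo at this place, para to a large group, without a number of its own. Putting tert-butyl in place of 3-methylphenyl on this aromatic carbon gives an at least 9.1-fold higher number from compound 1 to compound 4 (0.96 log units; beyond the scatter), which shows that four heavy atoms without a ring do not restore what compound 1 shows, so the gain is not tied to simply replacing bromo with more carbon. The steps among compound 2, compound 3 and compound 4 cannot be read: the limit of > 1000 nM in this assay, at which 3 of the 4 values shown sit.

The compounds shown leave open whether the gain in compound 1 comes from the added aromatic ring itself or from the methyl on it. A plain phenyl or a pyridyl at this place would bear on that question.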